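The source may report more compounds than this note shows. Statements on the series, on what has been measured and on what is new or still open speak of the compounds shown alone.

Measured compounds in an ADME assay on the whole organism with Oryza sativa as the target, tested at 1 uM; a higher number here means a weaker effect of the compound at the concentration tested, a lower number a stronger effect:
In this assay compound 1 `CCc1cccc(NC(=O)N[C@H](C)c2ccccc2)c1` gives 71%.
In this assay compound 2 `CC(C)c1cccc(NC(=O)N[C@H](C)c2ccccc2)c1` gives 61%.
In this assay compound 3 `C[C@@H](NC(=O)Nc1cccc(C(F)(F)F)c1)c1ccccc1` gives 72%.

Compound 3 carries the highest of the three numbers in this assay, but its separation from compound 1 is a number 1 percentage points higher from compound 1 to compound 3 (within the scatter), so the two are not distinguished; only against compound 2 does it stand apart, by a number 11 percentage points higher from compound 2 to compound 3 (beyond the scatter).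

Compound 4 `CCOC(=O)c1cccc(NC(=O)N[C@H](C)c2ccccc2)c1` differs from compound 3 in one place: ethoxycarbonyl in place of trifluoromethyl on an aromatic carbon.

The measured steps that change the group on this aromatic carbon are a number 1 percentage points higher from compound 1 to compound 3 (within the scatter) and a number 11 percentage points higher from compound 2 to compound 3 (beyond the scatter), with the related a number 10 percentage points lower from compound 1 to compound 2 (within the scatter). All three stay small, so exchanges at this position have moved this assay little so far. The ethoxycarbonyl group brings two hydrogen-bond acceptors where the trifluoromethyl group has none, which the measured set does not cover, so the range is widened. The expected step from compound 3 is a number 7 percentage points lower from compound 3 to compound 4 (within the scatter), not beyond the scatter. Compound 4 is estimated at 65%, in the range 48% to 80%.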

Compound 4, a percentage reported as activity, at one concentration (the size of the read-out at that concentration, not a potency): 94%
Beside the measured number, compound 4's estimate is 29 percentage points below it; measured number outside the range, above it.
By their numbers in this assay, from the lowest: compounds 2, 1 and 3 (each within the scatter of the next, the first and the last beyond it); then compound 4.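

In this assay the ethoxycarbonyl group gives the first steps at this aromatic carbon that clear the scatter against every other group shown: a number 22 percentage points higher from compound 3 to compound 4 (beyond the scatter), a number 23 percentage points higher from compound 1 to compound 4 (beyond the scatter) and a number 33 percentage points higher from compound 2 to compound 4 (beyond the scatter). The position therefore responds to more than the exchanges among ethyl, isopropyl and trifluoromethyl suggested, the widest of which was a number 11 percentage points higher from compound 2 to compound 3 (beyond the scatter), and compound 4 has the weakest effect of the four at the concentration tested. Ethoxycarbonyl is also the only group of the four with hydrogen-bond acceptors, but nothing available links that count or any other feature to this result.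

On these data alone, whether the step belongs to the carbonyl or to the ethyl part of the ester stays open. A carboxylic acid, a methyl ester or a primary amide on this aromatic carbon would separate the two.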